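The compounds below may be only part of what the source reports. "The series", "measured", "known", "first", "only" and "open" are said of these compounds alone.

The compounds gathered here were tested in a functional assay on the whole organism for inhibition, with Rattus norvegicus as the target, read by paw edema, with stated times of 1 h and 3 h, at a dose of 50 mg/kg by the oral route; on this read-out lower numbers stand for less inhibition and higher numbers for more inhibition at the one dose given (going by the name of the read-out). Compound 1 `C/C(=N\OCC(=O)O)c1ccccc1` is the smallest of them. In this assay compound 1 gives < 20%, which is a limit of the assay rather than a number. Compound 2 `C/C(=N\OCC(=O)O)c1ccc(CC2CCCCC2)cc1` carries cyclohexylmethyl in place of hydrogen on an aromatic carbon. In this assay compound 2 gives < 20%, again a limit. The step that the two limits leave unreadable from compound 1 to compound 2 therefore cannot be read. Compound 3 `CN(C)c1ccc(/C=N/OCC(=O)O)cc1` is the starting point of the present step. In this assay compound 3 gives < 20%, a limit and not a number, so compound 3 stands at the limit of < 20% in this assay, at which 3 of the 3 values shown sit, together with the other two.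

Compound 4 `O=C(O)CO/N=C/c1ccc([N+](=O)[O-])cc1` has not been measured. The change is nitro in place of dimethylamino on an aromatic carbon. For the measured compounds named here, no measured step touches a nitro group in place of dimethylamino, and the one step on record cannot be sized because both its ends sit at the limit of < 20% in this assay, at which 3 of the 3 values shown sit. Going by the values given here, nothing among the measured compounds points to a rise out of the limit, so no step beyond the scatter is expected. Compound 4 is therefore expected to give 15%, with a range from 3% to 32%. The step that the limit leaves unreadable from compound 3 to compound 4 that this estimate means is expected to stay within the scatter.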

Compound 4, a percentage reported as inhibition, in the whole organism at one dose (the size of the read-out at that dose, not a potency): < 20%
Compound 4: only a limit was reported (the forecaster's own chance of this, stated with the estimate: 70%); the middle value lies beyond the limit too.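

No step can be read from compound 3 to compound 4, because in this assay both compounds give only a limit and not a number: the limit of < 20% in this assay, at which 4 of the 4 values shown sit.

The compounds shown leave open whether compound 3 and compound 4 truly differ, and whether any change to the shared core gives a readable value in this assay.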